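A Phenyl in Place of an Ethoxycarbonyl on the Imine Carbon

The source may report more compounds than this note shows. Statements on the series, on what has been measured and on what is new or still open speak of the compounds shown alone.

Compound 3 `CCOC(=O)/C=N/c1cnc(Nc2ccc(S(N)(=O)=O)cc2)nc1NC(C)C` carries an ethoxycarbonyl group on a carbon with a double bond to nitrogen. In a functional assay on HT-29 cells (Homo sapiens) for antiproliferative activity, read by MTT assay (a lower number here means a stronger inhibitor, a higher number a weaker inhibitor), compound 3 gives only a limit, > 100000 nM, and no number. That value is the limit of > 100000 nM in this assay, at which 1 of the 3 values shown sits.

Two other measured compounds carry a phenyl on that carbon instead. Compound 1 `NS(=O)(=O)c1ccc(Nc2ncc(/N=C/c3ccccc3)c(NC3CCCC3)n2)cc1` gives 27000 nM in this assay. Compound 2 `CC(C)Nc1nc(Nc2ccc(N3CCN(C)CC3)cc2)ncc1/N=C/c1ccccc1` gives 12100 nM in this assay. Both are numbers rather than limits, and the two sit within the scatter of each other, so neither can be called the more potent.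

Compound 4 `CC(C)Nc1nc(Nc2ccc(S(N)(=O)=O)cc2)ncc1/N=C/c1ccccc1` is reached from compound 3 by one change, (phenyl in place of ethoxycarbonyl on a carbon with a double bond to nitrogen), that is, phenyl in place of ethoxycarbonyl on a carbon with a double bond to nitrogen; the rest of compound 3 is kept. For the measured compounds named here, no measured pair shows this step, so its size has to be expected rather than read. Compound 4 differs from compound 1 in one group and from compound 2 in another, and both of those compounds give numbers in this assay. Compound 4 is therefore expected to come in as a number, with a step of an at least 5.0-fold lower number from compound 3 to compound 4 (0.69 log units; beyond the scatter) towards stronger inhibition that goes beyond the scatter. The estimate for compound 4 in this assay is 20000 nM, between 6000 nM and 70000 nM.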

Compound 4, half-maximal inhibitory concentration: 98200 nM
Compound 4: middle estimate off by 4.9-fold (0.69 log units), on the low side; the measured number lies above the stated range.
By their numbers in this assay, from the lowest: compound 2; then compound 1; then compound 4. At a limit, above all of these: compound 3.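

Phenyl in place of ethoxycarbonyl on the carbon with a double bond to nitrogen gives only an at least 1.0-fold lower number from compound 3 to compound 4 (0.00 log units; that floor lies within the scatter), so this change alone is not shown to strengthen inhibition in this assay. The phenyl therefore does not by itself bring the lower numbers of the other two phenyl compounds, and the changes elsewhere are the ones with steps beyond the scatter: sulfamoyl in place of 4-methylpiperazin-1-yl on an aromatic carbon gives an 8.1-fold higher number from compound 2 to compound 4 (0.91 log units; beyond the scatter), and isopropyl in place of cyclopentyl on a nitrogen on an aromatic ring gives a 3.6-fold higher number from compound 1 to compound 4 (0.56 log units; beyond the scatter). Compound 3 remains a limit and not a number, which is why the true size of the phenyl step stays unknown: the limit of > 100000 nM in this assay, at which 1 of the 4 values shown sits.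

The compounds shown leave open how a methyl group, a carboxylic acid or a phenyl carrying a hydroxyl group on that same carbon would read in this assay. They also leave open whether cyclopentyl and 4-methylpiperazin-1-yl, when both stand in a single compound, would give a lower number than either does alone.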